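Amine substituent variation on the shared core

A few compounds are considered here, and "the series" means these few. Any claim that something is new, unique, unknown or untested is made for them only; others in the source may bear on it.

The two measured compounds share one core and differ only in the group on the saturated chain carbon bound to the amine nitrogen. Compound 1 `CC(C)=CCCN(C)C1CCN(CCCc2c[nH]c3ccc(-n4cnnc4)cc23)CC1` gives 2.6 nM in an assay on CHO cells for displacement of a labelled ligand from 5-hydroxytryptamine receptor 1D (Homo sapiens); on this read-out lower numbers stand for stronger inhibition and higher numbers for weaker inhibition. For the measured compounds named here, compound 2 `CN(Cc1ccsc1)C1CCN(CCCc2c[nH]c3ccc(-n4cnnc4)cc23)CC1` gives 1.5 nM in this assay, the lowest of the two numbers, with compound 1 as its nearest neighbour; the only measured step, a 1.7-fold lower number from compound 1 to compound 2 (0.24 log units; within the scatter), is within the scatter, so the two are not separated.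

Compound 3 `CN(Cc1ccc(S(C)(=O)=O)cc1)C1CCN(CCCc2c[nH]c3ccc(-n4cnnc4)cc23)CC1` has not been measured. It differs from compound 2 by 4-(methylsulfonyl)phenyl in place of thiophen-3-yl on a saturated chain carbon bound to an amine nitrogen. Going by the values given here, the one step that bears on this position, the step from compound 1 to compound 2, shows that exchanging the group on this chain carbon left the number essentially unchanged. Among the compounds with values here, no measured step covers the entry of a 4-(methylsulfonyl)phenyl group, so the expectation rests on that single small step alone.

The expected step of a 2.0-fold higher number from compound 2 to compound 3 (0.30 log units; within the scatter) is therefore small, with no direction claimed beyond the scatter. Compound 3 is estimated at 3 nM in this assay, with a range from 1 nM to 10 nM.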

Compound 3, half-maximal inhibitory concentration: 18 nM
For compound 3 the middle estimate is 6.0-fold (0.78 log units) below the measured one, outside the stated range (above it).
By their numbers in this assay, from the lowest: compounds 2 and 1 (each within the scatter of the next); then compound 3.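

In this assay, the place on a saturated chain carbon bound to an amine nitrogen is no longer indifferent to the group it carries: 4-(methylsulfonyl)phenyl in place of thiophen-3-yl gives a 12-fold higher number from compound 2 to compound 3 (1.08 log units; beyond the scatter), and 4-(methylsulfonyl)phenyl in place of 3-methylbut-2-en-1-yl gives a 6.9-fold higher number from compound 1 to compound 3 (0.84 log units; beyond the scatter). The tolerance suggested by the earlier pair therefore covers only thiophen-3-yl and 3-methylbut-2-en-1-yl, and it does not extend to this larger group, which brings a six-membered aromatic ring of carbon only and two double bonds outside aromatic rings. No evidence at hand accounts for the higher number.

Still open, on these data alone, is whether the higher number goes with the six-membered aromatic ring itself or with the methylsulfonyl group on it, a question that an unsubstituted benzyl group in this place would separate. Among the compounds shown, it also remains open whether a different group on the same ring, such as a methoxy group or a nitrile, would behave like methylsulfonyl or like thiophen-3-yl.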